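Benzyl removal on the thiophene series: expected effect

A few compounds are considered here, and "the series" means these few. Any claim that something is new, unique, unknown or untested is made for them only; others in the source may bear on it.

Compound 1 `COc1ccc(-c2sc(C(=O)O)cc2-c2cc(OC)c(OC)c(OC)c2)cc1OCc1ccccc1` in a functional assay on KB cells (Homo sapiens) for antiproliferative activity, read by MTT assay, with a stated time of 72 h (a higher number here means a weaker inhibitor, a lower number a stronger inhibitor), gives > 100000 nM, which is a limit of the assay. Compound 2 `COc1ccc(-c2sc(C(=O)O)cc2-c2cc(OC)c(OC)c(OC)c2)cc1O` in this assay gives 11200 nM. The change between them, (hydrogen in place of benzyl on an oxygen on an aromatic ring), gives an at least 8.9-fold lower number from compound 1 to compound 2 (0.95 log units; beyond the scatter); the true size of that step is open because of the limit of > 100000 nM in this assay, at which 2 of the 3 values shown sit. Compound 3 `COc1ccc(-c2ccsc2-c2cc(OC)c(OC)c(OC)c2)cc1OCc1ccccc1` carries a different core, and the difference between the two cores is not broken down here. In this assay compound 3 gives > 100000 nM, also a limit of the assay. Going by the values given here, compound 4 `COc1ccc(-c2ccsc2-c2cc(OC)c(OC)c(OC)c2)cc1O` differs from compound 3 by hydrogen in place of benzyl on an oxygen on an aromatic ring, the same change as the one between compound 1 and compound 2. The step of an at least 16-fold lower number from compound 3 to compound 4 (1.22 log units; beyond the scatter) is expected to be of a size comparable to an at least 8.9-fold lower number from compound 1 to compound 2 (0.95 log units; beyond the scatter), resting on compound 1 and compound 2 alone. Compound 4 is estimated at 6000 nM, expected between 600 nM and 60000 nM.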

Compound 4, half-maximal inhibitory concentration: 1530 nM
Compound 4: the middle estimate sits 3.9-fold (0.59 log units) above what was measured, within the range that was stated.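

Hydrogen in place of benzyl gives an at least 65-fold lower number from compound 3 to compound 4 (1.81 log units; beyond the scatter) in this assay. The direction of the change therefore carries over from the core of compound 1 to the core of compound 3: the same change on two cores in this assay, an at least 8.9-fold lower number (0.95 log units; beyond the scatter) from compound 1 to compound 2 and an at least 65-fold lower number (1.81 log units; beyond the scatter) from compound 3 to compound 4; the limit leaves it open whether they differ. The true size of neither step is shown, so nothing can be said about the change being worth more on one core than on the other: the limit of > 100000 nM in this assay, at which 2 of the 4 values shown sit.

Only hydrogen is shown in place of benzyl, so it remains open whether a methyl or a longer chain on the same oxygen would also give a lower number. Also open, from the compounds shown here alone, is what an amine in place of the hydroxy would do on either core.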